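The source may report more compounds than this note shows. Statements on the series, on what has been measured and on what is new or still open speak of the compounds shown alone.

Compound 1 `Cc1ccc(-c2nnc(SCCn3c([N+](=O)[O-])cnc3C)o2)cc1` gives 12500 nM in a functional assay on SGC-7901 cells (Homo sapiens) for cytotoxicity, read by MTT assay, with a stated time of 48 h; on this read-out higher numbers stand for weaker inhibition and lower numbers for stronger inhibition. Compound 2 `COc1ccc(-c2nnc(SCCn3c([N+](=O)[O-])cnc3C)o2)cc1` gives 10200 nM in this assay. Compound 3 `Cc1ncc([N+](=O)[O-])n1CCSc1nnc(-c2ccccc2F)o1` gives 33700 nM in this assay.

Compound 3 gives the highest number of the three and so the weakest inhibition: the change from compound 1 to compound 3 was a 2.7-fold higher number from compound 1 to compound 3 (0.43 log units; beyond the scatter), and the change from compound 2 to compound 3 was a 3.3-fold higher number from compound 2 to compound 3 (0.52 log units; beyond the scatter). Compounds 1 and 2 sit within the scatter of each other, so no order can be read between them.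

Compound 4 `Cc1ncc([N+](=O)[O-])n1CCSc1nnc(-c2ccccn2)o1` differs from compound 3 in one place: pyridin-2-yl in place of 2-fluorophenyl on an aromatic carbon. Within the data shown here, the only measured steps that bear on this position are those that swapped the 2-fluorophenyl for 4-methylphenyl or 4-methoxyphenyl, both modest in size. Among the measured compounds shown here, no measured compound carries a ring with a hetero atom at this position, so the direction of the step in this assay is uncertain. Compound 4 is therefore expected to fall near compound 3, and its estimated value is 25000 nM, within a range from 8000 nM to 80000 nM. This estimate corresponds to a 1.3-fold lower number from compound 3 to compound 4 (0.13 log units; within the scatter) in this assay.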

Compound 4, half-maximal inhibitory concentration: 30000 nM
For compound 4 the middle estimate is 1.2-fold (0.08 log units) below the measured one; measured number inside the range.
By their numbers in this assay, from the lowest: compounds 2 and 1 (each within the scatter of the next); then compounds 4 and 3 (each within the scatter of the next).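

Swapping 2-fluorophenyl for pyridin-2-yl, which brings a ring nitrogen and one hydrogen-bond acceptor to this position, gives no difference that can be read in this assay (a 1.1-fold lower number from compound 3 to compound 4 (0.05 log units; within the scatter)). Compound 4 stands apart from the 4-methoxyphenyl and 4-methylphenyl compounds (a 2.9-fold higher number from compound 2 to compound 4 (0.47 log units; beyond the scatter); a 2.4-fold higher number from compound 1 to compound 4 (0.38 log units; beyond the scatter)), so the first ring with a hetero atom here falls on the same side of that gap as compound 3. No measurement at hand explains this grouping.

The compounds shown leave open whether moving the ring nitrogen, as in pyridin-3-yl or pyridin-4-yl, would separate such a compound from compound 4. They also leave open how an amine or a carboxylic acid on the phenyl ring would compare with compound 1 and compound 2.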